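The source may hold more compounds than are shown below. What is called first, only, known or untested is meant among the compounds shown, and "the series" means these compounds.

The measured compounds so far:
Compound 1, `COc1cc(O)c(C(=O)/C=C/c2ccc(F)cc2)c(OC)c1`, gives "not active" (no number reported).
Compound 2, `COc1cc(OC)c(C(=O)/C=C/c2ccccc2SC)c(OC)c1`, gives 24%.
Compound 3, `COc1cc(O)c(C(=O)/C=C/c2ccccc2OC)c(OC)c1`, gives 49%.

In a functional assay on HaCaT cells (Homo sapiens), read by fluorescence and BrdU incorporation, with a stated time of 48 h, tested at 10 uM (a lower number here means a stronger effect, a higher number a weaker effect of the compound at the concentration tested), compound 3 stands highest of the two numbers reported, that is, it shows the weaker effect of the two. Its nearest neighbour is compound 2, whose number in this assay is lower by a margin beyond the usual scatter, so compound 2 does show the stronger effect. Compound 1 gave no number at all in this assay. Compound 2 and compound 3 differ in two places, so the gap between them cannot be assigned to any single change.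

The next compound, compound 4, `COc1cc(O)c(C(=O)/C=C/c2ccccc2SC)c(OC)c1`, differs from compound 3 in one place: methylsulfanyl in place of methoxy on an aromatic carbon. Among the measured compounds shown here, since no single-change step has been measured, the size of this step is open. For the measured compounds named here, the account can only note that the one compound bearing methylsulfanyl, compound 2, gave the lower number. On that basis the step from compound 3 to compound 4 is expected to run downward, toward a stronger effect, though the two-place difference makes this uncertain; the expected step is a number 14 percentage points lower from compound 3 to compound 4 (beyond the scatter). Compound 4 is therefore estimated at 35%, with a range from 15% to 60%.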

Compound 4, a percentage reported as activity, at one concentration (the size of the read-out at that concentration, not a potency): 51%
Compound 4: middle estimate off by 16 percentage points, on the low side, within the range that was stated.
By their numbers in this assay, from the lowest: compound 2; then compounds 3 and 4 (each within the scatter of the next).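

Methylsulfanyl in place of methoxy on an aromatic carbon, ortho to a large group, gives a number 2 percentage points higher from compound 3 to compound 4 (within the scatter) in this assay and is the first single change read at this position, so the two groups cannot be told apart here in this read-out. Hydrogen in place of methyl on an oxygen on an aromatic ring, by contrast, gives a number 27 percentage points higher from compound 2 to compound 4 (beyond the scatter) with methylsulfanyl held in place, a modest step toward a weaker effect and the only single change shown that moves the number beyond the scatter. No measurement among these compounds gives a reason for either step.

The compounds shown leave open whether the methyl on that oxygen carries the same weight when methoxy stands in place of methylsulfanyl, since that one-place pair is absent here. They also leave open how this aromatic carbon would respond to a group of another kind, such as an amine, a carboxylic acid or a longer chain like butoxy.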